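Hydroxy removal on a saturated ring carbon across two cores

A few compounds are considered here, and "the series" means these few. Any claim that something is new, unique, unknown or untested is made for them only; others in the source may bear on it.

Compound 1 `C=C1CC[C@@H]2CCc3coc(c3C2(C)C)C/C(C)=C/C(O)C1` and compound 2 `C=C1CC/C=C(\C)Cc2occ3c2C(C)(C)[C@H](CC1)CC3` share one core; compound 3 `C=C1CC[C@@H]2CCC3=C(C(=O)[C@@H](/C(C)=C/C(O)C1)[C@H]3O)C2(C)C` and compound 4 `C=C1CC/C=C(\C)[C@@H]2C(=O)C3=C(CC[C@@H](CC1)C3(C)C)[C@@H]2O` share another, and the difference between the two cores is not broken down here. In a functional assay on HT-29 cells (Homo sapiens) for cytotoxicity, read by MTT assay, with a stated time of 6 days (a lower number here means that less compound is needed, a higher number that more compound is needed for the effect), compound 1 gives 9.76 ug/mL. In this assay compound 2 gives 9.25 ug/mL. The change from compound 1 to compound 2 is hydrogen in place of hydroxy on a saturated ring carbon and it makes a 1.1-fold lower number from compound 1 to compound 2 (0.02 log units; within the scatter). For compound 3 this assay reports only a limit, > 50 ug/mL, which is the limit of > 50 ug/mL in this assay, at which 1 of the 3 values shown sits. From compound 3 to compound 4 the same kind of change is made, (hydrogen in place of hydroxy on a saturated ring carbon), the place here also having three ring bonds from the ring atom that bears a fused ring. Compound 4 is expected to give 60 ug/mL in this assay, estimated between 25 ug/mL and 150 ug/mL, with a step that the limit leaves unreadable from compound 3 to compound 4 expected to be small since the same kind of change gave a 1.1-fold lower number from compound 1 to compound 2 (0.02 log units; within the scatter).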

Compound 4, concentration for half-maximal effect: > 50 ug/mL
Compound 4 ended at the assay's limit; the forecaster's own chance of this, stated with the estimate: 65%; the middle value is on the limit's open side.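

Compound 3 and compound 4 both stand at a limit in this assay, so the step between them cannot be read: the limit of > 50 ug/mL in this assay, at which 2 of the 4 values shown sit.

From the compounds shown here alone, it remains open whether hydrogen in place of hydroxy acts on the core of compound 3 as it does on the core of compound 1.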